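Thiophen-3-yl for 5-ethylthiophen-2-yl on the amine carbon

A few compounds are considered here, and "the series" means these few. Any claim that something is new, unique, unknown or untested is made for them only; others in the source may bear on it.

Compound 1 `COc1ccc(CNc2ccc(-c3cnco3)c(OC)c2)cc1` in an ADME assay on Huh-7 cells (Homo sapiens) for cytotoxicity, read by MTT assay, with a stated time of 96 h (a lower number here means that less compound is tolerated, a higher number that more compound is tolerated), gives 41300 nM. Compound 3 `CCc1ccc(CNc2ccc(-c3cnco3)c(OC)c2)s1` in this assay gives 39100 nM, and this number and that of compound 1 sit within the scatter of each other. For compound 2 `COc1cc(/N=C/c2ccc(F)cc2)ccc1-c1cnco1` the result in this assay is a limit of the assay, > 100000 nM; it is the limit of > 100000 nM in this assay, at which 1 of the 3 values shown sits. Compound 4 `COc1cc(NCc2ccsc2)ccc1-c1cnco1` is not yet measured in this assay. It differs from compound 3 by thiophen-3-yl in place of 5-ethylthiophen-2-yl on a saturated chain carbon bound to a nitrogen on an aromatic ring. Among the measured compounds shown here, no pair of measured compounds differs in one place, so no measured step size is at hand. A small step toward a higher number, if any beyond the scatter, is expected: a 1.3-fold higher number from compound 3 to compound 4 (0.11 log units; within the scatter). Compound 4 is estimated in this assay at 50000 nM, between 25000 nM and 100000 nM.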

Compound 4, half-maximal cytotoxic concentration: 63100 nM
Compound 4: the middle estimate sits 1.3-fold (0.10 log units) below what was measured; the range from low to high includes it.
By their numbers in this assay, from the lowest: compounds 3, 1 and 4 (each within the scatter of the next). At a limit, above all of these: compound 2.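

In this assay, thiophen-3-yl in place of 5-ethylthiophen-2-yl gives a 1.6-fold higher number from compound 3 to compound 4 (0.21 log units; within the scatter). Among the compounds shown here, this is the first step that differs in one place, and it shows that this chain carbon carries the group with fewer heavy atoms with no change beyond the scatter. Nothing measured bears on a cause for this step. The step joins loss of the ethyl with a different thiophene attachment, and the compounds shown do not separate the two. Open too, from the compounds shown here alone, is whether an amine or carboxylic acid on the thiophene, or a longer chain in place of ethyl, would shift the number beyond the scatter.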